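The source may hold more compounds than are shown below. What is called first, only, known or untested is meant among the compounds shown, and "the series" means these compounds.

Of the compounds shown here, three of the shared core have been measured in a functional assay on HCT-15 cells (Homo sapiens) for inhibition, read by sulforhodamine B assay, with a stated time of 48 h; a higher number here means a weaker inhibitor of growth, a lower number a stronger inhibitor of growth. Compound 1 `COc1ccc(NC(=O)Nc2n[nH]c3ccccc23)cc1` reports only a limit in this assay, > 100000 nM. Compound 2 `CCCCOc1ccc(NC(=O)n2nc(N)c3ccccc32)cc1` gives 15500 nM in this assay, the lowest of the two numbers available, and compound 3 `Nc1nn(C(=O)Nc2c(F)cccc2F)c2ccccc12` gives 40900 nM in this assay, a gap beyond the usual scatter. Compound 4 `Nc1nn(C(=O)Nc2ccc(Cc3ccccc3)cc2)c2ccccc12` is not yet measured in this assay. It differs from compound 2 in one place: benzyl in place of butoxy on an aromatic carbon. The group leaving and the group entering are of comparable size, and the change is not covered by any measured step in this assay, so the step is expected to be small, a 1.3-fold lower number from compound 2 to compound 4 (0.11 log units; within the scatter), in either direction or none beyond the scatter. For compound 4 the estimate in this assay is 12000 nM, with a range of 4000 nM to 40000 nM.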

Compound 4, concentration for 50% growth inhibition: 1080 nM
The estimate for compound 4 lay 11-fold (1.05 log units) above the measured number; the measured number lies below the stated range.
By their numbers in this assay, from the lowest: compound 4; then compound 2; then compound 3. At a limit, above all of these: compound 1.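

On the aromatic carbon para to a large group, benzyl in place of butoxy gives a 14-fold lower number from compound 2 to compound 4 (1.16 log units; beyond the scatter) in this assay, so this position is sensitive to the group it carries, even between groups of comparable size. No measurement at hand accounts for the step. Among the compounds shown here, the single pair does not separate the entering six-membered aromatic ring from the leaving oxygen. Going by these compounds, a phenoxy group or a longer chain on the same carbon would bear on that question, and whether the step carries over to other substituents on this ring remains open.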